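The compounds below may be only part of what the source reports. "The series", "measured", "known", "first", "only" and "open" are said of these compounds alone.

Of the compounds shown here, three sharing one core have been tested in a functional assay on K562 cells (Homo sapiens) for cytotoxicity, read by CCK-8 assay, with a stated time of 72 h; on this read-out higher numbers stand for weaker inhibition and lower numbers for stronger inhibition. Compound 1 `COc1ccccc1/C=c1/[nH]c(=O)/c(=C\c2ccccc2OC)[nH]c1=O` is reported as "not active" (no number reported), with no number attached. Compound 2 `COc1ccccc1/C=c1\c(=O)[nH]/c(=C/c2cccc(Cl)c2Cl)c(=O)n1C` gives 110 nM, the lowest of the two numbers reported. Compound 3 `C=CCn1c(=O)/c(=C\c2cc(F)ccc2C)[nH]c(=O)/c1=C\c1ccccc1OC` gives 1800 nM, a higher number that lies beyond the usual scatter, so compound 3 is the weaker of the two. Compound 4 `COc1ccccc1/C=c1\c(=O)[nH]/c(=C/c2ccccc2Cl)c(=O)n1C` awaits measurement. Its difference from compound 2 is hydrogen in place of chloro on an aromatic carbon; cut one bond further out, this reads 2,3-dichlorophenyl to 2-chlorophenyl. Going by the values given here, no pair of measured compounds shows what removing one chloro does here, so the step is expected to be a modest loss, a 2.7-fold higher number from compound 2 to compound 4 (0.44 log units; beyond the scatter), not far beyond the scatter. Compound 4 is therefore expected to give about 300 nM, between 100 nM and 1000 nM.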

Compound 4, half-maximal inhibitory concentration: 110 nM
Compound 4: middle estimate off by 2.7-fold (0.44 log units), on the high side; the measured number falls inside the stated range.
By their numbers in this assay, from the lowest: compounds 2 and 4 (each within the scatter of the next); then compound 3.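

In this assay, going by these compounds alone, cutting 2,3-dichlorophenyl back to 2-chlorophenyl gives no change at the digits printed from compound 2 to compound 4 (within the scatter) and is the first comparison here of compounds differing in one place. At this aromatic carbon, ortho to a chloro group, hydrogen therefore serves as well as chloro, and the second chloro is not needed for this cytotoxicity. No measurement at hand explains this result. On these data alone, whether the remaining chloro can also be replaced by hydrogen stays open. So does the effect of an amine or a carboxylic acid at the same carbon.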